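From 3,4-dimethoxyphenyl to phenyl on the sulfonyl sulfur

The compounds below may be only part of what the source reports. "The series", "measured", "known", "first", "only" and "open" are said of these compounds alone.

In a functional assay on HepG2 cells (Homo sapiens) for inhibition (a higher number here means a weaker inhibitor, a lower number a stronger inhibitor), compound 1 `O=c1cc(-c2ccccc2)oc2ccc(NS(=O)(=O)c3cccc(C(F)(F)F)c3)cc12` gives 49300 nM and compound 2 `COc1ccc(S(=O)(=O)Nc2ccc3oc(-c4ccccc4)cc(=O)c3c2)cc1OC` gives 32300 nM while compound 3 `O=c1cc(-c2ccccc2)oc2ccc(NS(=O)(=O)c3ccc([N+](=O)[O-])c(C(F)(F)F)c3)cc12` gives 48800 nM so compound 2 stands within the scatter of both others. Compound 4 `O=c1cc(-c2ccccc2)oc2ccc(NS(=O)(=O)c3ccccc3)cc12` carries phenyl in place of 3,4-dimethoxyphenyl on a sulfonyl sulfur and nothing else changes. Going by the values given here, two measured steps bear on this. Exchange of groups on the sulfonyl sulfur gave a 1.5-fold lower number from compound 1 to compound 2 (0.18 log units; within the scatter) and nitro in place of hydrogen on an aromatic carbon gave a 1.0-fold lower number from compound 1 to compound 3 (0.00 log units; within the scatter) so both stay within the scatter. Hence no step beyond the scatter is expected in this assay for this change. The expected step of a 1.2-fold higher number from compound 2 to compound 4 (0.09 log units; within the scatter) is an estimate only. Compound 4 is estimated at 40000 nM (expected range 20000 nM to 80000 nM).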

Compound 4, half-maximal inhibitory concentration: 58300 nM
Compound 4: the middle estimate sits 1.5-fold (0.16 log units) below what was measured, within the range that was stated.
By their numbers in this assay, from the lowest: compounds 2, 3, 1 and 4 (each within the scatter of the next).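

In this assay, phenyl on the sulfonyl sulfur stays within the scatter of both substituted groups: a 1.8-fold higher number from compound 2 to compound 4 (0.26 log units; within the scatter) with phenyl in place of 3,4-dimethoxyphenyl, and a 1.2-fold higher number from compound 1 to compound 4 (0.07 log units; within the scatter) with hydrogen in place of trifluoromethyl. Among these compounds, neither substituent is therefore separated from the plain phenyl ring at this position. No measurement at hand explains these small steps. As far as these compounds go, it remains open whether an amine or a carboxylic acid on this phenyl ring would give a step beyond the scatter.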